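A Pyrazole Replaces the Pyridin-4-yl Group on the Amide Nitrogen

A few compounds are considered here, and "the series" means these few. Any claim that something is new, unique, unknown or untested is made for them only; others in the source may bear on it.

Of the compounds shown here, three sharing one core have been measured in an assay on HEK293 cells for agonist activity at transient receptor potential cation channel subfamily M member 8 (Homo sapiens), read by fluorescence and calcium flux, with a stated time of 15 min; a lower number here means that less compound is needed, a higher number that more compound is needed for the effect. Compound 1 `Cc1ccc(OCC(=O)N(Cc2cccs2)c2cccnc2)cc1` gives 198 nM, compound 2 `CON(Cc1cccs1)C(=O)COc1ccc(C)cc1` gives 10 nM, and compound 3 `Cc1ccc(OCC(=O)N(Cc2cccs2)c2ccncc2)cc1` gives 52 nM. Compound 3 thus stands second highest of the three: the step of a 3.8-fold lower number from compound 1 to compound 3 (0.58 log units; beyond the scatter) and the step of a 5.2-fold higher number from compound 2 to compound 3 (0.72 log units; beyond the scatter) both lie beyond the scatter. Compound 4 `Cc1ccc(OCC(=O)N(Cc2cccs2)c2c[nH]nc2C)cc1` differs from compound 3 only in the group on the amide-type nitrogen: 3-methyl-1H-pyrazol-4-yl in place of pyridin-4-yl on an amide-type nitrogen. Among the measured compounds shown here, the two measured steps that alter this same group, a 3.8-fold lower number from compound 1 to compound 3 (0.58 log units; beyond the scatter) and a 5.2-fold higher number from compound 2 to compound 3 (0.72 log units; beyond the scatter), were modest and ran in opposite directions, so the group here shifts the number, yet no measured step brings in a ring with a hydrogen-bond donor. A modest step of uncertain direction is therefore expected for compound 4, estimated at 80 nM with a range from 25 nM to 300 nM. That estimate for compound 4 amounts to a 1.5-fold higher number from compound 3 to compound 4 (0.19 log units; within the scatter).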

Compound 4, half-maximal effective concentration: 0.4 nM
Estimate against measurement, compound 4: 200-fold (2.30 log units) above; the measured number lies below the stated range.
By their numbers in this assay, from the lowest: compound 4; then compound 2; then compound 3; then compound 1.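

In this assay, among the compounds shown here, the group on the amide-type nitrogen proves able to move the number much further than the earlier steps showed: a 130-fold lower number from compound 3 to compound 4 (2.11 log units; beyond the scatter), a 25-fold lower number from compound 2 to compound 4 (1.40 log units; beyond the scatter), and a 500-fold lower number from compound 1 to compound 4 (2.69 log units; beyond the scatter). Among these four compounds, only compound 4 carries a hydrogen-bond donor in this group, and it has the lowest number. Nothing available explains this drop.

Still open, as far as these compounds go, is whether the donor, the methyl group or the five-membered ring accounts for the change. A plain 1H-pyrazol-4-yl or an imidazolyl group at this position would help separate these possibilities.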